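Methyl on the Amide Nitrogen in Two Settings

This account rests on a few compounds, and the source may have more. Where it says the series, first, only, none or still open, it means among the compounds named here.

Compound 1 `CC(=O)Nc1cccc2c1nc(-c1c(F)cccc1F)n2Cc1c(F)cccc1F`: in a toxicity assay on CCRF-CEM cells (Homo sapiens) for cytotoxicity (on this read-out lower numbers stand for higher toxicity in this test and higher numbers for lower toxicity in this test), compound 1 gives 39.3 uM.
Compound 2 `CC(=O)N(C)c1cccc2c1nc(-c1c(F)cccc1F)n2Cc1c(F)cccc1F`: in this assay compound 2 reaches only the limit > 100 uM, a limit and not a number.
Compound 3 `CC(=O)NCc1cccc2c1nc(-c1c(F)cccc1F)n2Cc1c(F)cccc1F`: in this assay compound 3 gives 20.8 uM.

The three share one core and differ at a single aromatic carbon. From compound 1 to compound 3 the change is acetamidomethyl in place of acetamido on an aromatic carbon, and in this assay this gave a 1.9-fold lower number from compound 1 to compound 3 (0.28 log units; within the scatter). From compound 1 to compound 2 the change is methyl in place of hydrogen on an amide-type nitrogen, and it gave an at least 2.5-fold higher number from compound 1 to compound 2 (0.40 log units; beyond the scatter); compound 2 sits at the limit of > 100 uM in this assay, at which 1 of the 3 values shown sits. Between compound 2 and compound 3 the data show an at least 4.8-fold lower number from compound 2 to compound 3 (0.68 log units; beyond the scatter).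

Compound 4 `CC(=O)N(C)Cc1cccc2c1nc(-c1c(F)cccc1F)n2Cc1c(F)cccc1F` has not been measured in this assay. It differs from compound 3 by methyl in place of hydrogen on an amide-type nitrogen. This is the same kind of change as from compound 1 to compound 2, not the same one: there the amide nitrogen's other neighbours were aromatic carbon and carbonyl carbon, here they are carbonyl carbon and saturated chain carbon. Resting on the step of an at least 2.5-fold higher number from compound 1 to compound 2 (0.40 log units; beyond the scatter), an upward step a 2.4-fold higher number from compound 3 to compound 4 (0.38 log units; beyond the scatter) is expected for compound 4. Compound 4 is therefore estimated at 50 uM, between 20 uM and 130 uM.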

Compound 4, half-maximal toxic concentration: 20.6 uM
Beside the measured number, compound 4's estimate is 2.4-fold (0.39 log units) above it; measured number inside the range.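

Placing the methyl on the amide nitrogen of compound 3 gave a 1.0-fold lower number from compound 3 to compound 4 (0.00 log units; within the scatter) in this assay, so the upward step seen with the acetamido group did not reappear with the acetamidomethyl group: the same change on two cores in this assay, an at least 2.5-fold higher number (0.40 log units; beyond the scatter) from compound 1 to compound 2 and a 1.0-fold lower number (0.00 log units; within the scatter) from compound 3 to compound 4; the limit leaves it open whether they differ

The other two steps read a 1.9-fold lower number from compound 1 to compound 4 (0.28 log units; within the scatter) and an at least 4.8-fold lower number from compound 2 to compound 4 (0.68 log units; beyond the scatter), the latter resting on a limit and not a number. The comparison shows that the step from compound 1 to compound 2 cannot simply be assumed on the other core, but with one pair per core and one end of that pair a limit, it does not show that the two steps truly differ.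

The compounds shown leave open what an ethyl group on the same amide nitrogen would give on either core. They also leave open whether a longer chain between the aromatic carbon and the amide, or an amine in place of the amide, would keep the numbers of compound 3 and compound 4.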